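Adding one hydroxy group to compound 2

This account rests on a few compounds, and the source may have more. Where it says the series, first, only, none or still open, it means among the compounds named here.

Compound 1 `O=C(N/N=C/c1cccc(O)c1O)c1ccc2ccccc2n1` gives 99600 nM in an ADME assay on U-937 cells (Homo sapiens) for cytotoxicity, read by MTT assay, with a stated time of 72 h; a higher number here means that more compound is tolerated, a lower number that less compound is tolerated
Compound 2 `O=C(N/N=C/c1ccc(O)cc1O)c1ccc2ccccc2n1` gives 11700 nM in this assay

Compound 2 holds the lower of these two numbers, so less of it is tolerated, and its gap to compound 1 lies beyond the usual scatter. Compound 3 `O=C(N/N=C/c1ccc(O)c(O)c1O)c1ccc2ccccc2n1` differs from compound 2 by one change hydroxy in place of hydrogen on an aromatic carbon and so carries hydroxy in place of hydrogen on an aromatic carbon, ortho to two hydroxy groups. Within the data shown here, no measured pair shows this change alone, so the expectation is loose. A small upward step is expected in this assay with a 1.7-fold higher number from compound 2 to compound 3 (0.23 log units; within the scatter) as the estimate. Compound 3 is estimated at 20000 nM with 5000 nM to 80000 nM as the expected range.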

Compound 3, concentration lethal to 50% of the cells: 221000 nM
The estimate for compound 3 lay 11-fold (1.04 log units) below the measured number, and the stated range ends below it.
By their numbers in this assay, from the lowest: compound 2; then compound 1; then compound 3.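

In this assay, hydroxy in place of hydrogen on an aromatic carbon, ortho to two hydroxy groups, gives a 19-fold higher number from compound 2 to compound 3 (1.28 log units; beyond the scatter) and so moves the number far beyond the scatter. The same kind of change at a different carbon of that ring gives a 2.2-fold higher number from compound 1 to compound 3 (0.35 log units; beyond the scatter), a modest step, so the size of the step differs with the starting compound. Nothing at hand explains why the number rises. From the compounds shown here alone, whether an amine, a methoxy group or a fluorine at this position would also raise the number stays open.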